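Dropping One Chlorine from a Sigma-1 Ligand

The compounds below may be only part of what the source reports. "The series", "measured", "known", "first", "only" and "open" are said of these compounds alone.

Compound 2 `O=C(C1CCN(Cc2ccc(Cl)cc2Cl)CC1)N1CCCc2ccccc21` carries a 2,4-dichlorobenzyl group on the shared core. In an assay for displacement of a labelled ligand from Sigma non-opioid intracellular receptor 1 (Cavia porcellus) (a lower number here means a stronger inhibitor, a higher number a weaker inhibitor), compound 2 gives 138 nM. Among the three measured compounds it stands second highest: compound 3 `O=C(NC1CCCCC1)C1CCN(Cc2ccc(Cl)cc2Cl)CC1` gives 52 nM, a lower number beyond the scatter, while compound 1 `CC(C)NC(=O)C1CCN(Cc2ccc(Cl)cc2)CC1` gives 637 nM, a higher number, also beyond the scatter. Compound 4 `O=C(C1CCN(Cc2ccc(Cl)cc2)CC1)N1CCCc2ccccc21` differs from compound 2 in one place: hydrogen in place of chloro on an aromatic carbon. Among the compounds with values here, no measured pair shows this change on its own, so the expectation rests on compound 2 alone. Taking away the chloro is expected to weaken binding modestly, by a step of about a 2.5-fold higher number from compound 2 to compound 4 (0.40 log units; beyond the scatter), with uncertainty in both directions. Compound 4 is therefore estimated at 350 nM, within a likely range from 120 nM to 1000 nM.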

Compound 4, inhibition constant: 3.7 nM
The estimate for compound 4 lay 95-fold (1.98 log units) above the measured number; the whole stated range lies above it.
By their numbers in this assay, from the lowest: compound 4; then compound 3; then compound 2; then compound 1.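

Replacing this one chloro with hydrogen, 2,4-dichlorobenzyl to 4-chlorobenzyl, gives a 37-fold lower number from compound 2 to compound 4 (1.57 log units; beyond the scatter) in this assay and so marks a large gain in binding. A change of a single heavy atom at this position, ortho to a large group, can therefore decide much of the binding strength, which compound 2 alone could not reveal. Nothing at hand explains why the step is so large.

From the compounds shown here alone, whether hydrogen is the best group here stays open, since a fluoro, methyl or methoxy group at this position could bind better or worse. Equally open, going by these compounds, is whether removing the same chloro from compound 3 would bring a similar gain.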